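The compounds below may be only part of what the source reports. "The series", "measured", "known", "first", "only" and "open" are said of these compounds alone.

The measured compounds:

compound 1 `COc1cccc2c1C(=O)C(C)(C)CO2`, 5.9%
compound 2 `C#CCN(Cc1ccccc1)C1c2cccc(OC)c2OCC1(C)C`, 14.7%
compound 3 `CC1(C)COc2ccccc2C1=O`, 9.2%

All three were tested in an assay on BTI cells for inhibition of Amine oxidase [flavin-containing] B (Homo sapiens), read by fluorescence, with a stated time of 20 min, tested at 1 uM; a higher number here means more inhibition at the concentration tested (going by the name of the read-out), a lower number less inhibition. In this assay compound 1 gives 5.9%, compound 3 gives 9.2% and compound 2 gives 14.7%. These three numbers lie within the usual scatter of one another, so none of the compounds can be set apart from the others on this evidence.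

Compound 1 and compound 3 differ in one place: hydrogen in place of methoxy on an aromatic carbon. The step of a number 3.3 percentage points higher from compound 1 to compound 3 (within the scatter) is within the scatter. How the core of compound 2 differs from the core of compound 1 is not broken down here, since the two differ in more than one place.

Compound 4 `C#CCN(Cc1ccccc1)C1c2ccccc2OCC1(C)C` has not yet been measured. It stands to compound 2 as compound 3 stands to compound 1: hydrogen in place of methoxy on an aromatic carbon. The place of the change is described in the same words in both pairs, so it is the same change, made twice among these compounds.

Because the earlier step of a number 3.3 percentage points higher from compound 1 to compound 3 (within the scatter) stayed within the scatter, a similarly small step is expected here, a number 1.3 percentage points higher from compound 2 to compound 4 (within the scatter). Compound 4 is therefore estimated at 16%, with a likely range from 5% to 28%.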

Compound 4, a percentage reported as inhibition, at one concentration (the size of the read-out at that concentration, not a potency): 2.9%
Estimate against measurement, compound 4: 13.1 percentage points above, outside the stated range (below it).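

In this assay, hydrogen in place of methoxy on an aromatic carbon gives a clear drop on the core of compound 2, a step of a number 11.8 percentage points lower from compound 2 to compound 4 (beyond the scatter), so on this core the methoxy-bearing compound 2 stands apart from its hydrogen counterpart compound 4. The same change does not behave alike on the two cores, and the effect seen on one could not be carried over to the other: the same change on two cores in this assay, a number 3.3 percentage points higher (within the scatter) from compound 1 to compound 3 and a number 11.8 percentage points lower (beyond the scatter) from compound 2 to compound 4, 15.1 percentage points apart, beyond the scatter of two such steps This rests on a single pair of compounds for each core, each read at one concentration, so it shows that the outcome of the change depends on the core here, but it does not show which part of the core is responsible, why the two cores differ, or how the change would behave on any further core.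

The compounds shown leave open whether another group on that aromatic carbon, such as a hydroxyl, an ethoxy or a chlorine, would keep the inhibition seen with methoxy on the core of compound 2. They also leave open which of the several differences between the core of compound 1 and the core of compound 2 decides how the change turns out.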